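This account rests on a few compounds, and the source may have more. Where it says the series, first, only, none or still open, it means among the compounds named here.

Measured compounds:
- Compound 1 `Oc1ccc(Cl)cc1-n1ccnc1`: 2100 nM
- Compound 2 `Oc1ccccc1-c1nnc[nH]1`: 31000 nM
- Compound 3 `Nc1ccccc1-c1nnc[nH]1`: 2000 nM

Of the compounds shown here, three have been tested in an assay on cells for inhibition of Indoleamine 2,3-dioxygenase 1 (Homo sapiens), read by HPLC, with a stated time of 20 min; on this read-out higher numbers stand for weaker inhibition and lower numbers for stronger inhibition. Compound 2 gives 31000 nM, the highest number of the three. Compound 3 gives 2000 nM, and compound 1 gives 2100 nM; these two numbers lie within the scatter of each other, so neither can be called the stronger. For the measured compounds named here, the one measured step, a 16-fold lower number from compound 2 to compound 3 (1.19 log units; beyond the scatter), shows a large change from a single swap of groups.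

Compound 4 `Nc1ccc(Cl)cc1-c1nnc[nH]1` differs from compound 3 by chloro in place of hydrogen on an aromatic carbon. Going by the values given here, no measured pair shows the effect of adding chloro on its own: compound 1 already carries a chloro, but the chloro-free partner of compound 1 was not tested, so its value of 2100 nM only shows that a chloro-bearing compound can reach the same range as compound 3. The step from compound 3 to compound 4 is therefore estimated as a modest move toward a lower number, a 2.9-fold lower number from compound 3 to compound 4 (0.46 log units; beyond the scatter), with wide uncertainty. Compound 4 is expected to give about 700 nM, within a range of 200 nM to 2500 nM.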

Compound 4, half-maximal inhibitory concentration: 35 nM
Compound 4: the middle estimate sits 20-fold (1.30 log units) above what was measured, outside the stated range (below it).
By their numbers in this assay, from the lowest: compound 4; then compounds 3 and 1 (each within the scatter of the next); then compound 2.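

Adding a single chloro to compound 3 has a large effect in this assay (a 57-fold lower number from compound 3 to compound 4 (1.76 log units; beyond the scatter)), so this carbon of the six-membered aromatic ring, para to an amino group and meta to a group of 5 heavy atoms, is highly sensitive to substitution. For the compounds shown here, this is the first pair to isolate chloro, and it shows that one added heavy atom can shift the number a long way, just as the earlier swap of hydroxy for amino did (a 16-fold lower number from compound 2 to compound 3 (1.19 log units; beyond the scatter)). Nothing available explains why this chloro has such an effect.

As far as these compounds go, whether fluoro, bromo or methyl on the same carbon would give a similar step remains open. It is also unknown whether chloro would have the same effect on compound 2, which carries hydroxy in place of the amino group.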